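Dropping one methyl on an aromatic carbon from compound 3

The source may hold more compounds than are shown below. What is called first, only, known or untested is meant among the compounds shown, and "the series" means these compounds.

Compound 1 `CCCC/C=C\CCCCCCCCCc1cc(=O)c2c(O)cc(OCOC)c(C)c2o1` gives > 87000 nM in a functional assay on MDA-MB-231 cells (Homo sapiens) for antiproliferative activity, read by MTT assay (on this read-out lower numbers stand for stronger inhibition and higher numbers for weaker inhibition), which is a limit of the assay and not a number.
Compound 2 `CCCCC/C=C\C/C=C\CCCCCCCc1cc(=O)c2c(O)c(C)c(OCOC)c(C)c2o1` gives 16100 nM in this assay.
Compound 3 `CCCC/C=C\CCCCCCCCCc1cc(=O)c2c(O)c(C)c(OCOC)c(C)c2o1` gives > 87000 nM in this assay, again a limit rather than a number.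

Compound 3 therefore stands at the limit of > 87000 nM in this assay, at which 2 of the 3 values shown sit, so only a limit is known for it. Compound 4 `CCCC/C=C\CCCCCCCCCc1cc(=O)c2c(O)c(C)c(OCOC)cc2o1` differs from compound 3 by hydrogen in place of methyl on an aromatic carbon. The nearest measured comparison is a step that the two limits leave unreadable from compound 1 to compound 3, which joins two limits and cannot be read. The step of an at least 5.4-fold higher number from compound 2 to compound 3 (0.73 log units; beyond the scatter) changes the chain, not the methyl, and bears little on this change. With compound 1 and compound 3 both at the limit, no step beyond the scatter is expected for compound 4, estimated as a step that the limit leaves unreadable from compound 3 to compound 4. Compound 4 is expected at 100000 nM, most likely reported again only as a limit, within 40000 nM to 300000 nM.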

Compound 4, half-maximal inhibitory concentration: > 87000 nM
Compound 4: no number, only a limit; the forecaster's own chance of this, stated with the estimate: 70%; the middle value does not contradict the limit.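

Compound 4 gives > 87000 nM in this assay, a limit and not a number. Among the compounds shown here, compound 3 is also known only as a limit, so no step between compound 3 and compound 4 can be read. Going by these compounds, whether hydrogen in place of methyl on this aromatic carbon changes the activity at all stays open.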